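Methoxy in Place of Hydrogen: Compound 1 to Compound 3

The compounds below may be only part of what the source reports. "The series", "measured", "known", "first", "only" and "open" are said of these compounds alone.

Of the compounds shown here, two sharing a common core have been measured so far. Compound 1 `O=C(C(Nc1ccccc1)c1ccc(C(F)(F)F)cc1)N1CCCC1c1ccccc1` gives 60 nM in an assay on HEK293 cells for antagonist activity at transient receptor potential M8 protein (Canis lupus familiaris), read by fluorescence and calcium flux, with a stated time of 5 min (on this read-out lower numbers stand for stronger inhibition and higher numbers for weaker inhibition), the highest of the two numbers recorded; its nearest neighbour is compound 2 `O=C(C(Nc1ccccc1)c1ccc(C(F)(F)F)cc1)N1CCCC1c1ccccc1F`, which gives 30 nM. For the measured compounds named here, the single measured step, a 2.0-fold lower number from compound 1 to compound 2 (0.30 log units; within the scatter), set a fluoro in place of hydrogen on an aromatic carbon and moved the number only within the scatter.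

Compound 3 `COc1ccccc1C1CCCN1C(=O)C(Nc1ccccc1)c1ccc(C(F)(F)F)cc1` has not yet been measured. It differs from compound 1 by methoxy in place of hydrogen on an aromatic carbon, on an aromatic carbon of a six-membered aromatic ring of carbon only, ortho to a large group; cut one bond further out, the change reads phenyl to 2-methoxyphenyl. Going by the values given here, only the step from compound 1 to compound 2 bears on this change, and that step stayed within the scatter. Methoxy is a different group from fluoro, and no measured step tells how it behaves here. The expected step for compound 3 is therefore a 1.2-fold lower number from compound 1 to compound 3 (0.08 log units; within the scatter), nothing beyond the scatter. The estimate for compound 3 in this assay is 50 nM, within 15 nM to 160 nM.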

Compound 3, half-maximal inhibitory concentration: 33 nM
The estimate for compound 3 lay 1.5-fold (0.18 log units) above the measured number; the measured number falls inside the stated range.
By their numbers in this assay, from the lowest: compounds 2, 3 and 1 (each within the scatter of the next).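

The new compound adds a second substituent to the place already probed by fluoro: an aromatic carbon of a six-membered aromatic ring of carbon only, ortho to a large group. In this assay, methoxy, with its 2 heavy atoms, gives a 1.8-fold lower number from compound 1 to compound 3 (0.26 log units; within the scatter), so this larger group, like fluoro, produces no step beyond the scatter. The direct exchange of the two substituents gives a 1.1-fold higher number from compound 2 to compound 3 (0.04 log units; within the scatter), which means that hydrogen, fluoro and methoxy at this place cannot be told apart by this read-out, and no other information on these compounds accounts for that result.

The compounds shown leave open whether an amine, a carboxylic acid or a longer chain such as ethoxy on this same aromatic carbon would give a step beyond the scatter, or whether the tolerance seen across these three compounds extends to such groups at all. They also leave open how methoxy would read on the other aromatic carbons of this ring, since every substituent shown here sits ortho to a large group.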